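Swapping the amide ring from pyrrolidine to piperidine

The source may report more compounds than this note shows. Statements on the series, on what has been measured and on what is new or still open speak of the compounds shown alone.

Measured so far, in an assay for activation of interferon regulatory factor 3 (Homo sapiens), read by a luciferase reporter, with a stated time of 20 h; on this read-out lower numbers stand for an effect already at smaller amounts and higher numbers for an effect only at larger amounts of compound:
- Compound 1 `COc1cc(C(N)=O)cc2nc(NC(=O)c3ccccn3)n(CCCNC(=O)OCc3ccccc3)c12` gives > 100000 nM, which is a limit of this assay.
- Compound 2 `CCn1nccc1C(=O)Nc1nc2cc(C(N)=O)cc(OC)c2n1CCCNC(=O)OCc1ccccc1` gives > 100000 nM, also a limit.
- Compound 3 `COc1cc(C(N)=O)cc2nc(NC(=O)C3CCCN3C)n(CCCNC(=O)OCc3ccccc3)c12` gives > 100000 nM, again a limit.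

All three compounds share one core and differ only in the ring attached to the carbonyl carbon of the amide; none of them shows an effect within the range the assay can report, as the limit of > 100000 nM in this assay, at which 3 of the 3 values shown sit, states. The steps between them, a step that the two limits leave unreadable from compound 1 to compound 2, a step that the two limits leave unreadable from compound 1 to compound 3 and a step that the two limits leave unreadable from compound 2 to compound 3, therefore cannot be sized, since limits at both ends hide any difference.

Compound 4 `COc1cc(C(N)=O)cc2nc(NC(=O)C3CCN(C)CC3)n(CCCNC(=O)OCc3ccccc3)c12` takes the step (1-methylpiperidin-4-yl in place of 1-methylpyrrolidin-2-yl on a carbonyl carbon). Among the measured compounds shown here, it is the fourth variation of the same ring position, and every measured variation so far ended at the limit. On that basis a step of the expected size a number no higher from compound 3 to compound 4 (the limit leaves the size open) is the best guess, which is to say none that the assay could show. Compound 4 is therefore expected to give about 100000 nM, within the range 30000 nM to 300000 nM, most likely reported as a limit once more.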

Compound 4, half-maximal effective concentration: > 100000 nM
Compound 4: a limit, no number; the forecaster's own chance of this, stated with the estimate: 85%; the middle value lies on the limit itself.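

Compound 4 ends at a limit, as do compound 1, compound 2 and compound 3, so no step among these four compounds can be read: the limit of > 100000 nM in this assay, at which 4 of the 4 values shown sit. The compounds shown leave open whether any group on this carbonyl carbon can give a readable value, and how far apart these four compounds truly lie.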